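The source may report more compounds than this note shows. Statements on the series, on what has been measured and on what is new or still open speak of the compounds shown alone.

In a physicochemical assay for solubility, at pH 7.4 (on this read-out lower numbers stand for lower solubility and higher numbers for higher solubility), the measured compounds read as follows:
Compound 1 `Cc1c2c(n3c1CCCNC[C@H](C)Nc1cc-3ccc1C(N)=O)CC(C)(C)CC2=O` gives > 100 ug/mL as a limit of the assay.
Compound 2 `Cc1c2c(n3c1CCN(C(=O)[C@H](C)N)CC[C@H](C)Nc1cc-3ccc1C(N)=O)CC(C)(C)CC2=O` gives > 100 ug/mL as a limit of the assay.
Compound 3 `CC[C@H](N)C(=O)N1CCc2c(C)c3c(n2-c2ccc(C(N)=O)c(c2)N[C@@H](C)[C@H](C)C1)CC(C)(C)CC3=O` gives > 100 ug/mL as a limit of the assay.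

All three therefore share one reading, and the series shows the limit of > 100 ug/mL in this assay, at which 3 of the 3 values shown sit, without any exact number. Compound 3 stands there too: its > 100 ug/mL is a limit and not a number.

The next compound is compound 4 `Cc1c2c(n3c1CCN(C(=O)C1(N)CCCC1)C[C@@H](C)[C@H](C)Nc1cc-3ccc1C(N)=O)CC(C)(C)CC2=O`. It carries 1-aminocyclopentyl in place of 1-aminopropyl on a carbonyl carbon, and the count of that change is 1-aminocyclopentyl in place of 1-aminopropyl on a carbonyl carbon in full.

Among the measured compounds shown here, no pair of measured compounds differs in one place, so no measured step guides the size of this one. In this assay no change beyond the scatter is expected, and the estimated step is a number no higher from compound 3 to compound 4 (the limit leaves the size open) as a working figure. The assay may well report only a limit again. For compound 4 the estimate is 100 ug/mL with an expected range from 50 ug/mL to 200 ug/mL in this reading.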

Compound 4, solubility: 53 ug/mL
Compound 4: the middle estimate sits 1.9-fold (0.28 log units) above what was measured; measured number inside the range.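

In this assay, compound 4 gives the first exact number among the compounds shown, so the group on this carbonyl carbon can now be followed on a read-out that is not a limit of the assay. Setting 1-aminocyclopentyl in place of 1-aminopropyl gives an at least 1.8-fold lower number from compound 3 to compound 4 (0.27 log units; that floor lies within the scatter), and only this floor is known, so the real size of the step stays open. The earlier compounds could show no such step at this place, and the shared reading is a limit: the limit of > 100 ug/mL in this assay, at which 3 of the 4 values shown sit.

The compounds shown leave open whether the five-membered ring itself matters or only the larger group, which an open-chain group such as 1-amino-1-methylethyl or a ring such as 1-aminocyclohexyl on the same carbonyl carbon would address. They also leave open what a hydroxyl in place of the amine on this group would read.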